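A few compounds are considered here, and "the series" means these few. Any claim that something is new, unique, unknown or untested is made for them only; others in the source may bear on it.

Three compounds in this series carry the same core and differ only in the aryl group on the anilino nitrogen. Compound 1 `CC(=O)N1CCN(c2ccc(Nc3ncc(C(F)(F)F)c(N4Cc5cccc(N(C)S(C)(=O)=O)c5C4)n3)cc2)CC1` gives 1400 nM in a functional assay on HepG2 cells (Homo sapiens) for antiproliferative activity, read by spectrophotometry, with a stated time of 2 days; a higher number here means a weaker inhibitor of growth, a lower number a stronger inhibitor of growth. Compound 3 `CN(c1cccc2c1CN(c1nc(Nc3ccc(Nc4ccccc4)cc3)ncc1C(F)(F)F)C2)S(C)(=O)=O` gives 8600 nM, and the change a 6.1-fold higher number from compound 1 to compound 3 (0.79 log units; beyond the scatter) shows that swapping this group can shift growth inhibition well beyond the scatter. Compound 2 `Cc1ccc(Nc2ncc(C(F)(F)F)c(N3Cc4cccc(N(C)S(C)(=O)=O)c4C3)n2)c(Cl)c1` yields only a limit, > 30000 nM, so its true value is not known (the limit of > 30000 nM in this assay, at which 1 of the 3 values shown sits); it stands at the weak end of the numbers seen so far.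

Compound 4 `COc1cc(Nc2ncc(C(F)(F)F)c(N3Cc4cccc(N(C)S(C)(=O)=O)c4C3)n2)cc(C(F)(F)F)c1` is the next variation: 3-methoxy-5-(trifluoromethyl)phenyl in place of 2-chloro-4-methylphenyl on a nitrogen on an aromatic ring. Within the data shown here, no measured step covers this exact swap, and the one step that exists concerns a different part of the phenyl ring, so the direction from compound 2 is uncertain. The aryl groups that did give numbers, in compound 1 and compound 3, both carried a nitrogen-bearing substituent, which compound 4 lacks. Compound 4 is therefore expected to remain a weak inhibitor, near 15000 nM with a range of 4000 nM to 60000 nM, a step of an at least 2.0-fold lower number from compound 2 to compound 4 (0.30 log units; that floor lies within the scatter) that is itself an estimate.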

Compound 4, concentration for 50% growth inhibition: 22100 nM
Beside the measured number, compound 4's estimate is 1.5-fold (0.17 log units) below it; low and high end bracket the measured number.
By their numbers in this assay, from the lowest: compound 1; then compound 3; then compound 4. At a limit, above all of these: compound 2.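

In this assay compound 4 gives 22100 nM as a measured number. It shows that an aryl group with no nitrogen-bearing substituent can still give a real reading here, which compound 1 and compound 3 could not show, and compound 4 goes against the impression that only such substituents give numbers. From the compounds shown here alone, the change from 2-chloro-4-methylphenyl to 3-methoxy-5-(trifluoromethyl)phenyl is an at least 1.3-fold lower number from compound 2 to compound 4 (0.13 log units; that floor lies within the scatter) and that figure is only a floor, so the true size of the change stays unknown, as compound 2 has a limit and not a number: the limit of > 30000 nM in this assay, at which 1 of the 4 values shown sits.

The compounds shown leave open whether the methoxy or the trifluoromethyl group matters more in compound 4, as the two appear only together. Also open, going by these compounds, is how a phenyl carrying a morpholine ring or a free amine would read in this assay on the same core.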